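From Dichlorophenyl to Benzodioxin: What to Expect of Compound 4

The source may hold more compounds than are shown below. What is called first, only, known or untested is meant among the compounds shown, and "the series" means these compounds.

Compound 1 `O=S(=O)(NCCNCc1ccc(-c2ccccc2)cc1)c1cc(C(F)(F)F)cc(C(F)(F)F)c1` gives 2400 nM in a functional assay on Capan-2 cells (Homo sapiens) for inhibition, read by MTT assay, with a stated time of 72 h; a higher number here means a weaker inhibitor of growth, a lower number a stronger inhibitor of growth.
Compound 2 `O=S(=O)(NCCCCNCc1ccc(Br)cc1)c1cc(C(F)(F)F)cc(C(F)(F)F)c1` gives 1900 nM.
Compound 3 `O=S(=O)(NCCCNCc1ccc(Cl)c(Cl)c1)c1cc(C(F)(F)F)cc(C(F)(F)F)c1` gives 1800 nM.

Compound 3 gives the lowest number of the three, but its gaps to compound 2 and to compound 1 are both within the scatter, so the three cannot be told apart. Among the compounds with values here, the only step between compounds that differ in a single place, a 1.1-fold lower number from compound 2 to compound 3 (0.02 log units; within the scatter), is itself within the scatter.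

Compound 4 `O=S(=O)(NCCCNCC1COc2ccccc2O1)c1cc(C(F)(F)F)cc(C(F)(F)F)c1` has not been measured. Its change from compound 3 is 2,3-dihydro-1,4-benzodioxin-2-yl in place of 3,4-dichlorophenyl on a saturated chain carbon bound to an amine nitrogen. Within the data shown here, no measured step bears directly on this change: each measured compound carries a substituted aromatic ring at that place, and none carries a non-aromatic ring fused to an aromatic one. The one step available, a 1.1-fold lower number from compound 2 to compound 3 (0.02 log units; within the scatter), was within the scatter, and the whole set spans less than the scatter, so among these three compounds changes at the amine end have not produced large shifts. The expected step of a 1.7-fold higher number from compound 3 to compound 4 (0.22 log units; within the scatter) is therefore small, leaning toward a somewhat higher number, with a larger move in either direction not excluded. Compound 4 is estimated at 3000 nM in this assay, with a range from 1200 nM to 8000 nM.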

Compound 4, concentration for 50% growth inhibition: 2500 nM
Beside the measured number, compound 4's estimate is 1.2-fold (0.08 log units) above it; low and high end bracket the measured number.
By their numbers in this assay, from the lowest: compounds 3, 2, 1 and 4 (each within the scatter of the next).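

In this assay, the step of a 1.4-fold higher number from compound 3 to compound 4 (0.14 log units; within the scatter) shows that this place on the chain can carry something other than a substituted aromatic ring bound directly to the saturated chain carbon, without the number moving beyond the scatter. The earlier compounds shown here could not show this, since each of them carries a substituted aromatic ring there, whereas the 2,3-dihydro-1,4-benzodioxin-2-yl of compound 4 brings a non-aromatic ring with two oxygen atoms and no chlorine, so in this pair the exchange of 3,4-dichlorophenyl for that group leaves the growth inhibition indistinguishable. No measurement of any property of these two groups is available to account for this result.

The compounds shown leave open whether the oxygen atoms of the new ring matter at all, which 1,2,3,4-tetrahydronaphthalen-2-yl, with carbon in their place, would test, and whether a cyclohexyl ring or a pyridine ring at the same place would give a step beyond the scatter. As far as these compounds go, it also remains open whether 2,3-dihydro-1,4-benzodioxin-2-yl would behave the same way on a longer chain.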